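Iodovinyl to hydroxypentynyl on a deoxyuridine scaffold

The source may hold more compounds than are shown below. What is called first, only, known or untested is meant among the compounds shown, and "the series" means these compounds.

Of the compounds shown here, three have been measured in an ADME assay on L1210/0 cells (Mus musculus) for cytotoxicity, with a stated time of 48 h; a lower number here means a stronger inhibitor, a higher number a weaker inhibitor. Compound 1 `Cc1ccc(-c2ncnc3c2ncn3C[C@@H]2C[C@H](CO)c3ccccc32)cc1` gives 15400 nM, and compound 2 `COC1=C(OC)/C(=C/Cn2cnc3c(Cl)ncnc32)OC1=O` gives 14000 nM. Compound 3 `O=c1[nH]c(=O)n([C@H]2C[C@H](O)[C@@H](CO)O2)cc1/C=C/I` gives 63900 nM, the highest of the three numbers; its gaps to compound 1 and to compound 2 both lie beyond the scatter, so compound 3 is the weakest inhibitor of the three. Compound 4 `O=c1[nH]c(=O)n([C@H]2C[C@H](O)[C@@H](CO)O2)cc1C#CCCCO` has not yet been measured. It differs from compound 3 in one place: 5-hydroxypent-1-yn-1-yl in place of 2-iodoethenyl on an aromatic carbon. Going by the values given here, no measured pair shows this change, so nothing here tells its size. The step of a 1.1-fold higher number from compound 3 to compound 4 (0.04 log units; within the scatter) is expected to stay within the scatter, leaning toward a slightly higher number. Compound 4 is therefore expected to give about 70000 nM in this assay, with a range from 15000 nM to 300000 nM.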

Compound 4, half-maximal inhibitory concentration: > 200000 nM
Compound 4: no number, only a limit; the forecaster's own chance of this, stated with the estimate: 30%; middle value at least 2.8-fold (0.45 log units) from the limit.
By their numbers in this assay, from the lowest: compounds 2 and 1 (each within the scatter of the next); then compound 3. At a limit, above all of these: compound 4.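

At this position, two atoms from the ring nitrogen, 5-hydroxypent-1-yn-1-yl in place of 2-iodoethenyl gives an at least 3.1-fold higher number from compound 3 to compound 4 (0.49 log units; beyond the scatter) in this assay, the first single-place change seen in this set. The change therefore weakens inhibition rather than leaving it unchanged. Compound 4 gives > 200000 nM, which is a limit and not a number, so the step has a lower bound but no known size.

The compounds shown do not separate the effect of the triple bond from that of the hydroxyl. A pent-1-yn-1-yl chain without the hydroxyl, or with an amine in its place, would bear on that question.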